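This account rests on a few compounds, and the source may have more. Where it says the series, first, only, none or still open, it means among the compounds named here.

Compound 1 `O=S(=O)(Nc1ccc(Cl)c(Cl)c1)c1ccc(-c2cnc(C3CC3)o2)cc1`: 62100 nM
Compound 2 `O=S(=O)(Nc1ccc(Cl)c(F)c1)c1ccc(-c2cnc(C3CC3)o2)cc1`: 63000 nM
Compound 3 `O=S(=O)(Nc1ccc(F)cc1F)c1ccc(-c2cnc(C3CC3)o2)cc1`: 66100 nM

In a functional assay on cells (leukaemia cell line, Homo sapiens) for inhibition, read by sulforhodamine B assay, with a stated time of 48 h (a higher number here means a weaker inhibitor of growth, a lower number a stronger inhibitor of growth), compound 3 gives 66100 nM, a value within the scatter of the other two: a 1.0-fold higher number from compound 2 to compound 3 (0.02 log units; within the scatter) and a 1.1-fold higher number from compound 1 to compound 3 (0.03 log units; within the scatter). Compound 4 `O=S(=O)(Nc1ccc(I)c(Cl)c1)c1ccc(-c2cnc(C3CC3)o2)cc1` carries 3-chloro-4-iodophenyl in place of 2,4-difluorophenyl on a sulfonamide nitrogen. The closest evidence comes from the changes to this same group, and the third such step, a 1.0-fold higher number from compound 1 to compound 2 (0.01 log units; within the scatter), is just as small. From the compounds shown here alone, none of the three measured compounds contains iodine, so that part of the change is untested and the range is kept wide. The expected step is a 1.1-fold lower number from compound 3 to compound 4 (0.04 log units; within the scatter), with no shift beyond the scatter anticipated. For compound 4 the estimated value is 60000 nM, with an expected range of 35000 nM to 90000 nM.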

Compound 4, concentration for total growth inhibition: 19600 nM
For compound 4 the middle estimate is 3.1-fold (0.49 log units) above the measured one; measured number below the stated range.
By their numbers in this assay, from the lowest: compound 4; then compounds 1, 2 and 3 (each within the scatter of the next).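

In this assay the group on the sulfonamide nitrogen, which had made no difference beyond the scatter, now does: exchanging a chloro for an iodo gives a 3.2-fold lower number from compound 1 to compound 4 (0.50 log units; beyond the scatter) and so separates compound 4 from compound 1. The comparisons with the other two groups agree, with a 3.2-fold lower number from compound 2 to compound 4 (0.51 log units; beyond the scatter) and a 3.4-fold lower number from compound 3 to compound 4 (0.53 log units; beyond the scatter) so that compound 4 alone stands apart. Nothing measured here accounts for this shift. From the compounds shown here alone, whether iodine alone suffices or the 3-chloro group is also needed remains open. So does whether bromo or trifluoromethyl in place of iodo would give the same step.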